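A few compounds are considered here, and "the series" means these few. Any claim that something is new, unique, unknown or untested is made for them only; others in the source may bear on it.

Measured compounds:
compound 1 `CCCOc1ccc(C(CC(=O)O)c2ccccc2)cc1` — 4.8 uM
compound 2 `CCCCCOc1ccc(C(CC(=O)O)c2ccccc2)cc1` — 2.97 uM

Both compounds share one core and differ only in the length of a straight chain attached through an oxygen on an aromatic ring. In a functional assay on HEK293 cells for agonist activity at Free fatty acid receptor 1 (Homo sapiens), read by calcium flux (on this read-out higher numbers stand for an effect only at larger amounts of compound and lower numbers for an effect already at smaller amounts), compound 1 gives 4.8 uM. In this assay compound 2 gives 2.97 uM, the lowest of the two numbers shown, but only by a 1.6-fold lower number from compound 1 to compound 2 (0.21 log units; within the scatter), so the two values cannot be told apart. Compound 3 `CCCCCCCOc1ccc(C(CC(=O)O)c2ccccc2)cc1` carries the same change once more: ethyl in place of hydrogen on a saturated chain carbon, five bonds along the chain from an oxygen on an aromatic ring. Within the data shown here, the only comparable step, a 1.6-fold lower number from compound 1 to compound 2 (0.21 log units; within the scatter), stayed within the scatter, so lengthening the chain again is expected to move this assay little, if at all, with at most a small shift toward a lower number. Compound 3 is therefore expected to give about 2.4 uM, between 0.9 uM and 6.5 uM, a step of a 1.2-fold lower number from compound 2 to compound 3 (0.09 log units; within the scatter) that would itself lie within the scatter.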

Compound 3, concentration for half-maximal effect: 4.26 uM
Compound 3: the middle estimate sits 1.8-fold (0.25 log units) below what was measured; low and high end bracket the measured number.
By their numbers in this assay, from the lowest: compounds 2, 3 and 1 (each within the scatter of the next).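

Adding ethyl five bonds along the chain from an oxygen on an aromatic ring gives, in this assay, a 1.4-fold higher number from compound 2 to compound 3 (0.16 log units; within the scatter) and so, like the earlier extension, produces no readable change. Taken as a whole, butyl in place of hydrogen three bonds along the chain from that oxygen gives a 1.1-fold lower number from compound 1 to compound 3 (0.05 log units; within the scatter) and shows that even the largest change in this series leaves the compounds indistinguishable, so the three chain lengths cannot be told apart here. Nothing available explains why these chains read alike.

The compounds shown leave open whether a much longer chain, or a branched one, would move the number beyond the scatter. They also leave open what an amine, a hydroxyl or a phenyl ring at the end of the chain would do.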